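The source may report more compounds than this note shows. Statements on the series, on what has been measured and on what is new or still open speak of the compounds shown alone.

Measured so far in a functional assay on SMMC-7721 cells (Homo sapiens) for antiproliferative activity, read by CCK-8 assay, with a stated time of 72 h; on this read-out higher numbers stand for weaker inhibition and lower numbers for stronger inhibition:

- Compound 1 `CCc1ccc(SCc2ccc(C(=O)Nc3ccccc3N)cc2)cc1` gives 1750 nM
- Compound 2 `Nc1ccccc1NC(=O)/C=C/c1ccc(CSc2cccc3ccccc23)cc1` gives "not determined" (no result reported)

Among the compounds with values here, compound 1 is the only compound with a number, so it cannot yet be ranked against anything and serves as a single reference point. Compound 3 `Cc1cc(C)cc(SCc2ccc(C(=O)Nc3ccccc3N)cc2)c1` has not been measured. It keeps the core of compound 1 and changes only the group on the sulfur, with 3,5-dimethylphenyl in place of 4-ethylphenyl on a sulfur as the whole difference. Within the data shown here, no measured pair shows what such a swap does, so nothing points to a shift in either direction. The expectation in this assay is therefore no change beyond the scatter, starting from compound 1 at 1750 nM as the only anchor. The expected step of a 1.0-fold lower number from compound 1 to compound 3 (0.01 log units; within the scatter) is accordingly small. For compound 3 the estimated value is 1700 nM with an expected range from 700 nM to 4200 nM here.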

Compound 3, half-maximal inhibitory concentration: 2760 nM
Compound 3: the middle estimate sits 1.6-fold (0.21 log units) below what was measured, within the range that was stated.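

In this assay, putting 3,5-dimethylphenyl in place of 4-ethylphenyl on a sulfur gives a 1.6-fold higher number from compound 1 to compound 3 (0.20 log units; within the scatter) and so leaves the two compounds indistinguishable. Within the data shown here, this pair provides the first measured comparison at this position, and it shows that rearranging the same carbon atoms around the ring, from one ethyl group to two methyl groups, does not separate compound 1 from compound 3 in this test. Nothing measured here offers an explanation for this result.

From the compounds shown here alone, both groups are carbon-only aromatic rings, so it remains open whether this position would respond to a more different group, such as a phenyl ring carrying an amine or a carboxylic acid. A longer carbon chain on the phenyl ring is equally untested in the compounds shown.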